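Aryl-to-cyclohexyl swap on silicon: expected potency

The compounds below may be only part of what the source reports. "The series", "measured", "known", "first", "only" and "open" are said of these compounds alone.

Measured compounds: compound 1 `CCN(C/C=C/C#CC(C)(C)C)Cc1cccc(OC[Si](C)(C)c2ccccc2C(F)(F)F)c1` gives 70 nM in a functional assay on liver (Sus scrofa) for inhibition of squalene monooxygenase (Homo sapiens), using microsomes; on this read-out lower numbers stand for stronger inhibition and higher numbers for weaker inhibition; compound 2 `CCN(C/C=C/C#CC(C)(C)C)Cc1cccc(OC[Si](C)(C)c2ccc(O)cc2)c1` gives 8000 nM; compound 3 `C=Cc1ccc([Si](C)(C)COc2cccc(CN(CC)C/C=C/C#CC(C)(C)C)c2)cc1` gives 70 nM.

Compound 3 stands level with compound 1 at the digits shown, the two together at the lowest numbers of the three; the step of no change at the digits printed from compound 1 to compound 3 (within the scatter) lies within the scatter. Compound 2 is the outlier: the step of a 110-fold higher number from compound 1 to compound 2 (2.06 log units; beyond the scatter) and the step of a 110-fold lower number from compound 2 to compound 3 (2.06 log units; beyond the scatter) are both large, and both involve the hydroxy group.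

Compound 4 `CCN(C/C=C/C#CC(C)(C)C)Cc1cccc(OC[Si](C)(C)C2CCCCC2)c1` is not yet measured. It differs from compound 3 by cyclohexyl in place of 4-vinylphenyl on a silicon. Within the data shown here, none of the measured steps covers a change from an aromatic to a non-aromatic ring at this silicon; the only step without a hydroxy group, from compound 1 to compound 3, showed no change, and the large steps both involve the hydroxy group that compound 4 lacks. A modest move in either direction within this assay is therefore expected, with a lean toward a somewhat higher number, a 2.1-fold higher number from compound 3 to compound 4 (0.33 log units; beyond the scatter). Compound 4 is estimated at 150 nM, in the range 40 nM to 600 nM.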

Compound 4, half-maximal inhibitory concentration: 20000 nM
Estimate against measurement, compound 4: 130-fold (2.12 log units) below; the whole stated range lies below it.
By their numbers in this assay, from the lowest: compounds 1 and 3 (each within the scatter of the next); then compound 2; then compound 4.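

In this assay, among these compounds, the ring on this silicon proves far less tolerant than the earlier compounds showed: cyclohexyl in place of 4-vinylphenyl gives a 290-fold higher number from compound 3 to compound 4 (2.46 log units; beyond the scatter), and cyclohexyl in place of 2-(trifluoromethyl)phenyl gives a 290-fold higher number from compound 1 to compound 4 (2.46 log units; beyond the scatter). Large rises at this position are therefore not confined to the hydroxy group. Cyclohexyl also stands beyond the 4-hydroxyphenyl ring, with a 2.5-fold higher number from compound 2 to compound 4 (0.40 log units; beyond the scatter), so all three aromatic rings shown give lower numbers than this one non-aromatic ring. Nothing available explains the size of these steps.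

The compounds shown leave open whether a phenyl, pyridyl or cyclohexenyl ring on this silicon would stay level with compound 1 and compound 3 or move toward compound 4. They also leave open whether an amine or a carboxylic acid on the aromatic ring would give a number as high as the hydroxy group does in compound 2.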